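Triazole nitrogen substituent series on a shared thiolactam core

The compounds below may be only part of what the source reports. "The series", "measured", "known", "first", "only" and "open" are said of these compounds alone.

Measured so far:
compound 1, `CCCn1nc(C(=O)N[C@H]2COc3ccccc3N(C)C2=S)nc1Cc1ccccc1`, 288 nM
compound 2, `CN1C(=S)[C@@H](NC(=O)c2nc(Cc3ccccc3)n(C3CCC3)n2)COc2ccccc21`, 181 nM

Both compounds were read in a functional assay on HT-29 cells (Homo sapiens) for inhibition, read by luminescence and CellTiter-Glo, with a stated time of 24 h; on this read-out higher numbers stand for an effect only at larger amounts of compound and lower numbers for an effect already at smaller amounts. Compound 1 gives 288 nM, compound 2 gives 181 nM. Within the data shown here, the only single-point step so far, a 1.6-fold lower number from compound 1 to compound 2 (0.20 log units; within the scatter), comes from cyclobutyl in place of propyl on an aromatic nitrogen. Compound 2 has the lowest of the two numbers, but its step to compound 1 lies within the scatter, so no order is established.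

Compound 3, `CN1C(=S)[C@@H](NC(=O)c2nc(Cc3ccccc3)n(CC3CCOC3)n2)COc2ccccc21`, is not yet measured in this assay. It differs from compound 2 by (oxolan-3-yl)methyl in place of cyclobutyl on an aromatic nitrogen. Among the measured compounds shown here, the one step that touches the same place, from compound 1 to compound 2, stayed within the scatter, so an exchange on this aromatic nitrogen has so far moved the number little. On that basis the step from compound 2 to compound 3 is expected to be small, a 1.4-fold higher number from compound 2 to compound 3 (0.14 log units; within the scatter), with no clear direction. Compound 3 is estimated at 250 nM, in the range 100 nM to 700 nM.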

Compound 3, half-maximal effective concentration: 4420 nM
For compound 3 the middle estimate is 18-fold (1.25 log units) below the measured one; the whole stated range lies below it.
By their numbers in this assay, from the lowest: compounds 2 and 1 (each within the scatter of the next); then compound 3.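

In this assay the exchange on this aromatic nitrogen is no longer a small matter: (oxolan-3-yl)methyl in place of cyclobutyl gives a 24-fold higher number from compound 2 to compound 3 (1.39 log units; beyond the scatter), and oxolan-3-yl in place of ethyl on a saturated chain carbon bound to an aromatic nitrogen gives a 15-fold higher number from compound 1 to compound 3 (1.19 log units; beyond the scatter). Compared with cyclobutyl, the entering group has more heavy atoms and adds an oxygen and a hydrogen-bond acceptor, so size and oxygen change together in this single step. No measurement at hand explains the higher number.

Whether the oxygen or the added size accounts for the step stays open; cyclopentylmethyl, the all-carbon counterpart of (oxolan-3-yl)methyl, would separate the two. On these data alone, how an amine or a carboxylic acid on this nitrogen substituent would read also remains open.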